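Swapping the Ring on the Hydrazide Carbonyl

This account rests on a few compounds, and the source may have more. Where it says the series, first, only, none or still open, it means among the compounds named here.

Measured compounds:
compound 1 `Cn1cnc(C(=O)NNC(=O)COc2c(F)cc(C(=O)c3ccc(F)cc3)cc2Cl)c1` — 40900 nM
compound 2 `Cn1cnc(C(=O)NNC(=O)COc2ccc(C(=O)c3ccccc3)cc2)c1` — 31900 nM
compound 3 `Cn1cnc(C(=O)NNC(=O)COc2c(F)cc(C(=O)c3ccc(Cl)cc3)cc2Cl)c1` — 54500 nM

These numbers come from a functional assay on HeLa cells (Homo sapiens) for cytotoxicity, read by LDH release, with a stated time of 48 h; on this read-out lower numbers stand for stronger inhibition and higher numbers for weaker inhibition. Compound 1 stands second highest of the three, with compound 2 a little lower and compound 3 a little higher, yet both gaps are within the usual scatter. Among the compounds with values here, the only single-point step measured so far, a 1.3-fold higher number from compound 1 to compound 3 (0.12 log units; within the scatter), is a halogen exchange on an aromatic carbon and stayed within the scatter.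

Compound 4 `O=C(COc1c(F)cc(C(=O)c2ccc(F)cc2)cc1Cl)NNC(=O)c1ccc(=O)oc1` differs from compound 1 in one place: a group of 7 heavy atoms (5 carbon, 2 oxygen; one six-membered aromatic ring with 1 hetero atom) in place of a group of 6 heavy atoms (4 carbon, 2 nitrogen; one five-membered aromatic ring with 2 hetero atoms), on a carbonyl carbon. Within the data shown here, no measured step touches the ring on the carbonyl carbon, so the data give no guidance on this exchange. The step of a 1.0-fold lower number from compound 1 to compound 4 (0.01 log units; within the scatter) is therefore expected to be none beyond the scatter. Compound 4 is estimated at 40000 nM, with a range from 15000 nM to 110000 nM.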

Compound 4, half-maximal inhibitory concentration: 60100 nM
For compound 4 the middle estimate is 1.5-fold (0.18 log units) below the measured one; the range from low to high includes it.
By their numbers in this assay, from the lowest: compounds 2, 1, 3 and 4 (each within the scatter of the next).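

Within the data shown here, the exchange of the 1-methyl-1H-imidazol-4-yl group for a six-membered aromatic ring on the carbonyl carbon gives a 1.5-fold higher number from compound 1 to compound 4 (0.17 log units; within the scatter) and is the first measured change at this place. In this one pair, a different ring size and different hetero atoms leave the number within the scatter. Nothing measured here offers an explanation for this result. The compounds shown leave open how a plain phenyl ring or a longer alkyl chain would read on this carbonyl carbon. They also leave open whether the same exchange would behave alike on the core of compound 2.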